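Swapping Isopropyl for Cyclopropyl on an Amide Nitrogen

This account rests on a few compounds, and the source may have more. Where it says the series, first, only, none or still open, it means among the compounds named here.

Within the data shown here, compound 1 `Cc1ccc(OCC(=O)N(Cc2cccs2)C(C)C)cc1` stands as the lower of the two numbers measured so far. In an assay on HEK293 cells for agonist activity at transient receptor potential cation channel subfamily M member 8 (Homo sapiens), read by fluorescence and calcium flux, with a stated time of 15 min (a lower number here means that less compound is needed, a higher number that more compound is needed for the effect), compound 1 gives 70 nM. Compound 2 `CCN(Cc1cccs1)C(=O)C[C@H](O)c1ccccc1` gives 52000 nM in this assay, a gap well beyond the usual scatter; its structure differs from compound 1 in several places at once, so no single change can be tied to that gap. Compound 3 `Cc1ccc(OCC(=O)N(Cc2cccs2)C2CC2)cc1` has not yet been measured. Among the measured compounds shown here, it differs from compound 1 in one place: cyclopropyl in place of isopropyl on an amide-type nitrogen No step between measured compounds shows how such a swap plays out here, so the expectation rests on the single change alone. The expected step is small, a 1.1-fold higher number from compound 1 to compound 3 (0.06 log units; within the scatter), within the usual scatter and with no clear direction. Compound 3 is therefore expected to give about 80 nM in this assay, most likely between 30 nM and 250 nM.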

Compound 3, half-maximal effective concentration: 8 nM
Estimate against measurement, compound 3: 10-fold (1.00 log units) above; the whole stated range lies above it.
By their numbers in this assay, from the lowest: compound 3; then compound 1; then compound 2.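

This step shows that the group on the amide-type nitrogen matters for more than its size in atoms. Isopropyl and cyclopropyl each have 3 carbon atoms, no hydrogen-bond donors or acceptors and no net charge, and the one difference counted between them is the three-membered ring. Even so, in this assay the swap gives an 8.8-fold lower number from compound 1 to compound 3 (0.94 log units; beyond the scatter), a change beyond the scatter, so less of compound 3 is needed for the effect. No measured data here explain why the ring has this effect.

On these data alone, it remains open whether a larger ring on this nitrogen, such as cyclobutyl, or a branched group such as tert-butyl, would lower the number further or raise it. As far as these compounds go, it is also open whether cyclopropyl would give a similar step if another part of the core were changed.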